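This account rests on a few compounds, and the source may have more. Where it says the series, first, only, none or still open, it means among the compounds named here.

In an ADME assay on TZM-b1 cells (Homo sapiens) for cytotoxicity, read by XTT assay, with a stated time of 3 days (on this read-out higher numbers stand for lower toxicity in this test and lower numbers for higher toxicity in this test), compound 1, with the structure `Cc1nc(C(NC(=O)C(=O)Nc2ccc(F)c(F)c2)C2CCCCN2)sc1CO`, sits at a limit of the assay and gives > 87000 nM. Compound 3, of structure `Cc1ccc(NC(=O)C(=O)NC(c2nc(C)c(CCO)s2)C2CCCCN2)c(F)c1`, also sits at a limit of this assay and gives > 78800 nM. Compound 2, of structure `Cc1nc(C(NC(=O)C(=O)Nc2ccc(Cl)cc2)C2CCCCN2C)sc1CCO`, gives a number in this assay, namely 36000 nM. Compound 1 thus stands among the values that end at a limit rather than at a number. Compound 4, of structure `Cc1ccc(NC(=O)C(=O)NC(c2nc(C)c(CO)s2)C2CCCCN2)cc1F`, remains to be measured in this assay. It differs from compound 1 in one place: methyl in place of fluoro on an aromatic carbon. Within the data shown here, no step between measured compounds isolates this change, so compound 4 is expected to show a step that the limit leaves unreadable from compound 1 to compound 4, none beyond the usual scatter. Compound 4 is accordingly estimated at 90000 nM, in a range from 40000 nM to 200000 nM, most likely again reported as a limit.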

Compound 4, half-maximal cytotoxic concentration: > 88000 nM
Compound 4 gave a limit, no number; the forecaster's own chance of this, stated with the estimate: 70%; the middle value lies beyond the limit too.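

Among these compounds, compound 1 and compound 4 both end at a limit in this assay, so no step between them can be read. The compounds shown leave open whether methyl in place of fluoro on an aromatic carbon changes this read-out at all.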